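The source may hold more compounds than are shown below. What is called first, only, known or untested is meant among the compounds shown, and "the series" means these compounds.

In an ADME assay on NHDF cells (Homo sapiens) for cytotoxicity, read by MTT assay, with a stated time of 72 h (on this read-out higher numbers stand for weaker inhibition and lower numbers for stronger inhibition), compound 1 `COc1ccc(/C=C2\CCC/C(=C\c3cccc(OC)c3OC)C2=O)cc1` gives 43500 nM and compound 2 `COc1ccc(/C=C2\CCC/C(=C\c3ccc(Cl)cc3)C2=O)cc1OC` gives 11200 nM as its result. Compound 2 therefore holds the lower of the two numbers, which means the stronger inhibition of this pair, and the gap between them lies beyond the usual scatter of repeated measurements.

Compound 3 `COc1ccccc1/C=C1\CCC/C(=C\c2ccc(OC)c(OC)c2)C1=O` has not yet been measured. It differs from compound 2 in one place, by 2-methoxyphenyl in place of 4-chlorophenyl on a double-bonded chain carbon bound to a double-bonded ring carbon in this change: 2-methoxyphenyl in place of 4-chlorophenyl on a double-bonded chain carbon bound to a double-bonded ring carbon.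

For the measured compounds named here, no pair of measured compounds shows what a single change of this kind does, so the only guide is the range set by the two known values. On that thin basis, a moderate rise in this assay is expected, towards weaker inhibition and smaller than the gap between the two measured compounds. The estimated move is a 2.1-fold higher number from compound 2 to compound 3 (0.33 log units; beyond the scatter) in size and direction. For compound 3 the expected value is 24000 nM as a central estimate. The estimated range for compound 3 runs from 9000 nM to 60000 nM at its two ends.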

Compound 3, half-maximal inhibitory concentration: 18100 nM
Estimate against measurement, compound 3: 1.3-fold (0.12 log units) above, within the range that was stated.
By their numbers in this assay, from the lowest: compounds 2 and 3 (each within the scatter of the next); then compound 1.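

In this assay, for the compounds shown here, the exchange of 4-chlorophenyl for 2-methoxyphenyl on a double-bonded chain carbon bound to a double-bonded ring carbon gives a 1.6-fold higher number from compound 2 to compound 3 (0.21 log units; within the scatter), and this is the first direct view of what a single change does at this place. The two compounds therefore cannot be told apart here: a ring carrying chlorine and a ring carrying a methoxy group, which brings one hydrogen-bond acceptor, give results that repeat measurements alone could separate by as much. Nothing available explains why the two groups read alike in this assay.

With only one exchange at this place, the compounds shown leave open whether the result would hold for a group of another kind, such as an aliphatic amine, a carboxylic acid or a longer alkyl chain in place of the aromatic ring. They also leave open how an unsubstituted phenyl would read, which would show whether the chlorine and the methoxy group each matter at all.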